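This account rests on a few compounds, and the source may have more. Where it says the series, first, only, none or still open, it means among the compounds named here.

Measured in a functional assay on Caco-2 cells (Homo sapiens) for inhibition, read by MTT assay, with a stated time of 48 h, tested at 10 uM; a higher number here means more inhibition of growth at the concentration tested, a lower number less inhibition of growth:

compound 1 `Cc1cc(=O)c2c(O)c(CN3CCC(N4CCCCC4)CC3)c(O)c([C@H]3CCN(C)C[C@H]3O)c2o1`: 31%
compound 2 `Cc1cc(=O)c2c(O)c(CN3CCN(C(=O)OC(C)(C)C)CC3)c(O)c([C@H]3CCN(C)C[C@H]3O)c2o1`: 21%
compound 3 `Cc1oc2c([C@H]3CCN(C)C[C@H]3O)c(O)cc(O)c2c(=O)c1C(O)c1ccccc1Br`: 7%

Of these three, compound 3 stands lowest at 7%, and its gaps to the other two lie beyond the scatter. The nearest is compound 2 at 21%, and the furthest is compound 1 at 31%. In compound 4 `Cc1oc2c([C@H]3CCN(C)C[C@H]3O)c(O)cc(O)c2c(=O)c1C(O)c1cccc(Cl)c1Cl`, 2,3-dichlorophenyl takes the place of 2-bromophenyl on a saturated chain carbon bound to an aromatic carbon and an oxygen on a saturated carbon (2,3-dichlorophenyl in place of 2-bromophenyl on a saturated chain carbon bound to an aromatic carbon and an oxygen on a saturated carbon). The rest of the structure stays as it is. Within the data shown here, no measured pair differs in one place, so the data do not show how far such a swap moves this assay. The expectation is therefore no step beyond the scatter, in either direction, and the estimate stays anchored on compound 3 at 7%. The expected change is small, a number 3 percentage points higher from compound 3 to compound 4 (within the scatter). Compound 4 is estimated to give 10%, with an expected range of 2% to 22%.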

Compound 4, percent growth inhibition at one concentration: 3%
For compound 4 the middle estimate is 7 percentage points above the measured one; the measured number falls inside the stated range.
By their numbers in this assay, from the lowest: compounds 4 and 3 (each within the scatter of the next); then compounds 2 and 1 (each within the scatter of the next).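

In this assay, among these compounds, the change from 2-bromophenyl to 2,3-dichlorophenyl on a saturated chain carbon bound to an aromatic carbon and an oxygen on a saturated carbon gives a number 4 percentage points lower from compound 3 to compound 4 (within the scatter) and this is the first step between compounds that differ in one place. At this position, then, replacing the one bromine with two chlorine atoms on the phenyl ring does not move the number beyond the scatter. No measurement at hand bears on why this step is so small.

Still open, on these data alone, is whether any other group at this position would shift the number beyond the scatter, such as an unsubstituted phenyl, a pyridine ring or a phenyl ring carrying a carboxylic acid. The steps from these two compounds to compound 1 and compound 2 cannot be read, since those compounds differ from them in more than one place.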